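Lengthening the iodine-bearing arm of compound 3

The source may report more compounds than this note shows. Statements on the series, on what has been measured and on what is new or still open speak of the compounds shown alone.

Compound 3 `O=C(CI)NCCCCCCCNc1ncnc2c1ncn2[C@@H]1O[C@H](COP(=O)(O)OP(=O)(O)OP(=O)(O)O)[C@@H](O)[C@H]1O` carries a shared core with an iodine-bearing arm. In an assay on isolated protein for inhibition of hexokinase-2 (Rattus norvegicus), with a stated time of 6 h, tested at 10 mM (on this read-out higher numbers stand for more inhibition at the one concentration tested (going by the name of the read-out) and lower numbers for less inhibition), compound 3 gives 30%, the highest of the three numbers measured. Compound 1 `O=C(CI)NCCCCC(=O)NCCCCCCNc1ncnc2c1ncn2[C@@H]1O[C@H](COP(=O)(O)OP(=O)(O)OP(=O)(O)O)[C@@H](O)[C@H]1O` gives 0% and compound 2 `O=C(CI)NCCCCCCC(=O)NCCCCCCNc1ncnc2c1ncn2[C@@H]1O[C@H](COP(=O)(O)OP(=O)(O)OP(=O)(O)O)[C@@H](O)[C@H]1O` gives 0%; the step of no change at the digits printed from compound 1 to compound 2 (within the scatter) shows that one enlargement of the arm made no difference. The step of a number 30 percentage points higher from compound 1 to compound 3 (beyond the scatter), by contrast, was a modest gain when the smaller group replaced the larger one. Compound 4 `O=C(I)NCC(=O)NCCCCCCNc1ncnc2c1ncn2[C@@H]1O[C@H](COP(=O)(O)OP(=O)(O)OP(=O)(O)O)[C@@H](O)[C@H]1O` moves the other way: a group of 8 heavy atoms (3 carbon, 2 nitrogen, 2 oxygen, 1 iodine; no ring) in place of a group of 6 heavy atoms (3 carbon, 1 nitrogen, 1 oxygen, 1 iodine; no ring), on a saturated chain carbon, six bonds along the chain from a nitrogen on an aromatic ring. Because a number 30 percentage points higher from compound 1 to compound 3 (beyond the scatter) rewarded the smaller group at this place, compound 4 is expected to lose some inhibition, a step of a number 22 percentage points lower from compound 3 to compound 4 (beyond the scatter). Compound 4 is estimated at 8%, within 0% to 25%.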

Compound 4, a percentage reported as inhibition, at one concentration (the size of the read-out at that concentration, not a potency): 0%
Compound 4: middle estimate off by 8 percentage points, on the high side; low and high end bracket the measured number.
By their numbers in this assay, from the lowest: compounds 1, 2 and 4 (each within the scatter of the next); then compound 3.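

In this assay the step of a number 30 percentage points lower from compound 3 to compound 4 (beyond the scatter) shows that the group of 8 heavy atoms does not keep the inhibition seen with (((iodomethyl)carbonyl)amino)methyl at this place. Shortening the arm does not bring that inhibition back: the steps of no change at the digits printed from compound 2 to compound 4 (within the scatter) and no change at the digits printed from compound 1 to compound 4 (within the scatter) leave compound 4 level with the two longer arms. Nothing at hand explains this result. Going by these compounds, whether a longer all-carbon chain or an amine within the arm would keep or raise the inhibition of compound 3 stays open.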